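Replacing But-1-en-1-yl with Hydroxymethyl on the Carbonyl Carbon

This account rests on a few compounds, and the source may have more. Where it says the series, first, only, none or still open, it means among the compounds named here.

In a functional assay on HCT-116 cells (Homo sapiens) for inhibition, read by MTT assay, with a stated time of 48 h (on this read-out lower numbers stand for stronger inhibition and higher numbers for weaker inhibition), compound 1 (`COCC(=O)N(Cc1ccc(OC)c(O)c1)c1cc(OC)c(OC)c(OC)c1`) gives 230 nM with methoxymethyl on the carbonyl carbon. Compound 2 (`CC/C=C/C(=O)N(Cc1ccc(OC)c(O)c1)c1cc(OC)c(OC)c(OC)c1`) gives 63 nM with but-1-en-1-yl at that place and so holds the lower of the two numbers, the stronger inhibition of the pair. Compound 3 (`COc1ccc(CN(C(=O)CO)c2cc(OC)c(OC)c(OC)c2)cc1O`) has not yet been measured. Going to it from compound 2 brings hydroxymethyl in place of but-1-en-1-yl on a carbonyl carbon as the change, hydroxymethyl in place of but-1-en-1-yl on a carbonyl carbon. Within the data shown here, the only measured step bearing on this is a 3.7-fold lower number from compound 1 to compound 2 (0.56 log units; beyond the scatter) at the same carbonyl carbon, a modest one. Among the measured compounds shown here, it shows what but-1-en-1-yl is worth against methoxymethyl, and hydroxymethyl itself has no measured example. A step of similar size or somewhat larger, toward a higher number, is therefore expected in this assay when but-1-en-1-yl leaves. The expected move is a 4.8-fold higher number from compound 2 to compound 3 (0.68 log units; beyond the scatter) on this estimate. For compound 3 the estimated value is 300 nM with 90 nM to 1000 nM as its expected range.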

Compound 3, half-maximal inhibitory concentration: 520 nM
Estimate against measurement, compound 3: 1.7-fold (0.24 log units) below, and the stated range covers the measured number.
By their numbers in this assay, from the lowest: compound 2; then compound 1; then compound 3.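

The result gives the carbonyl carbon a third point in this assay and shows that this position responds to small changes as well as large ones: exchanging but-1-en-1-yl for hydroxymethyl gives an 8.3-fold higher number from compound 2 to compound 3 (0.92 log units; beyond the scatter), and even the loss of a single methyl from the oxygen on a saturated carbon gives a 2.3-fold higher number from compound 1 to compound 3 (0.35 log units; beyond the scatter), beyond the scatter despite the small size of the change. The three groups therefore fall into a clear order, with but-1-en-1-yl giving the lowest number, methoxymethyl the middle one and hydroxymethyl the highest, so capping this oxygen with methyl recovers part of the ground without matching but-1-en-1-yl. Nothing available explains why these groups rank in this order, and no measurement beyond these numbers bears on it.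

The compounds shown leave open whether the advantage of but-1-en-1-yl depends on its double bond or simply on its four carbons, which a saturated butyl chain would help to separate. They also leave open how an aminomethyl group, a carboxylic acid or a longer ether chain at this carbonyl carbon would fall within this order.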